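The source may hold more compounds than are shown below. What is called first, only, known or untested is meant among the compounds shown, and "the series" means these compounds.

Measured compounds

Compound 1, `Cc1cc(C(C)C)ccc1OC(c1ccc(Cl)cc1)c1cnc(NC(=O)OC(C)(C)C)s1`: in an ADME assay on HepG2 2.2.15 cells (Homo sapiens) for cytotoxicity (a lower number here means that less compound is tolerated, a higher number that more compound is tolerated), compound 1 reaches only the limit of the assay, > 50000 nM.
Compound 2, `COCCc1ccc(OC(c2ccc(Cl)cc2)c2cnc(NC(=O)OC(C)(C)C)s2)cc1`: in this assay compound 2 likewise reaches only the limit of the assay, > 50000 nM.

Compound 2 therefore stands at a limit, not at a number, in this assay. Among the measured compounds shown here, the one further value shown is a limit as well, so both measurements sit at the limit of > 50000 nM in this assay, at which 2 of the 2 values shown sit. For the measured compounds named here, the single measured step, a step that the two limits leave unreadable from compound 1 to compound 2, runs from one limit to the other, and its size cannot be read from the two values.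

Compound 3, `Cc1cc(Br)cc(OC(c2ccc(Cl)cc2)c2cnc(NC(=O)OC(C)(C)C)s2)c1`, differs from compound 2 by 3-bromo-5-methylphenyl in place of 4-(2-methoxyethyl)phenyl on an oxygen on a saturated carbon. Going by the values given here, no measured step speaks to this change in a readable way: the only comparison available, between compound 1 and compound 2, shows two limits and nothing more. With both measured compounds at the limit, the author expects no step beyond the scatter and expects compound 3 to stay at the limit as well, the step of a number no higher from compound 2 to compound 3 (the limit leaves the size open) being essentially flat. The estimate for compound 3 in this assay is 50000 nM, with a range from 20000 nM to 100000 nM.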

Compound 3, half-maximal cytotoxic concentration: > 50000 nM
Compound 3 ended at the assay's limit (the forecaster's own chance of this, stated with the estimate: 80%); the middle value sits exactly at the limit.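

Among the compounds shown here, compound 3 also reaches only the limit of this assay, so no step among compound 1, compound 2 and compound 3 can be read, and all three stand together: the limit of > 50000 nM in this assay, at which 3 of the 3 values shown sit. The compounds shown leave open how far each lies beyond that limit, and whether any change to the group on the oxygen would bring a readable value.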